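This account rests on a few compounds, and the source may have more. Where it says the series, first, only, none or still open, it means among the compounds named here.

The measured compounds:
compound 1 `CCOC(=O)[C@H](CCC(=O)O)NC(=O)c1ccc(CNc2nc3cc(N)cc(N)c3nc2-c2ccccc2)cc1`, in a functional assay on NCI-H522 cells (Homo sapiens) for inhibition, read by sulforhodamine B assay, with a stated time of 48 h; on this read-out higher numbers stand for weaker inhibition of growth and lower numbers for stronger inhibition of growth: < 100000 nM, a limit of the assay rather than a number
compound 2 `Nc1cc(N)c2nc(-c3ccccc3)c(NCc3ccc(Cl)c(Cl)c3)nc2c1`, in this assay: 4900 nM

Among the compounds with values here, compound 2 holds the only actual number here. The value of compound 1 is a limit and not a number; it sits at the limit of < 100000 nM in this assay, at which 1 of the 2 values shown sits. Compound 3 `COc1ccc(CNc2nc3cc(N)cc(N)c3nc2-c2ccccc2)cc1OC` is not yet measured and differs from compound 2 in one place: 3,4-dimethoxyphenyl in place of 3,4-dichlorophenyl on a saturated chain carbon bound to a nitrogen on an aromatic ring. Within the data shown here, with no measured step to lean on, a modest weakening of growth inhibition is expected, a 2.4-fold higher number from compound 2 to compound 3 (0.39 log units; beyond the scatter), a step somewhat beyond the scatter. Compound 3 is estimated at 12000 nM, within 3000 nM to 45000 nM.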

Compound 3, concentration for total growth inhibition: 6310 nM
Compound 3: middle estimate off by 1.9-fold (0.28 log units), on the high side; measured number inside the range.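

In this assay, replacing 3,4-dichlorophenyl with 3,4-dimethoxyphenyl on the saturated chain carbon gives a 1.3-fold higher number from compound 2 to compound 3 (0.11 log units; within the scatter), so this position accepts both groups with no measurable difference. The two groups differ in their atoms, and the entering one has 2 hydrogen-bond acceptors where the leaving one has 0, yet the read-out does not separate them. Nothing measured here explains this result.

As far as these compounds go, whether a pyridine ring or a morpholine ring at this place would also leave growth inhibition unchanged remains open. So does the effect of a longer chain between the ring and the nitrogen.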